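Sulfonamide nitrogen series: from compound 3 to compound 4

This account rests on a few compounds, and the source may have more. Where it says the series, first, only, none or still open, it means among the compounds named here.

Of the compounds shown here, three have been read in a physicochemical assay for solubility, in phosphate buffer, measured as kinetic solubility, with a stated time of 24 h, at pH 7.4 (on this read-out higher numbers stand for higher solubility and lower numbers for lower solubility), and none gives a number. Compound 1 (`CC(C)CN(Cc1ccc(N2CCN(CS(C)(=O)=O)CC2)cc1)S(=O)(=O)Cc1ccccc1`) reports <= 1000 nM, which is a limit. Compound 2 (`CC(=O)N1CCN(c2ccc(CN(CC(C)C)S(=O)(=O)Cc3ccccc3)cc2)CC1`) reports <= 1000 nM, also a limit. Compound 3 (`CC(=O)N1CCN(c2ccc(CN(C(C)(C)C)S(=O)(=O)Cc3ccccc3)cc2)CC1`) reports <= 1000 nM, again a limit. The series therefore has one shared reading: the limit of <= 1000 nM in this assay, at which 3 of the 3 values shown sit.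

Compound 4 (`CCCN(Cc1ccc(N2CCN(C(C)=O)CC2)cc1)S(=O)(=O)Cc1ccccc1`) has propyl in place of tert-butyl on a sulfonamide nitrogen. One measured change sits at this place, tert-butyl in place of isobutyl, shown as a step that the two limits leave unreadable from compound 2 to compound 3. The change of acetyl in place of (methylsulfonyl)methyl on an amine nitrogen in a ring, shown as a step that the two limits leave unreadable from compound 1 to compound 2, lies elsewhere. Neither size can be read, so neither supports a direction.

The expected change in this assay is none beyond the scatter, and the estimated step is a step that the limit leaves unreadable from compound 3 to compound 4. A further limit is the most likely report. For compound 4 the estimate is 800 nM, with an expected range from 300 nM to 2000 nM.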

Compound 4, solubility: 40000 nM
Compound 4: middle estimate off by 50-fold (1.70 log units), on the low side; the measured number lies above the stated range.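

In this assay, among these compounds, the sulfonamide nitrogen now gives a readable change, where the earlier steps cannot be read: propyl in place of tert-butyl gives an at least 40-fold higher number from compound 3 to compound 4 (1.60 log units; beyond the scatter). Hydrogen in place of methyl on a saturated chain carbon bound to two saturated chain carbons, which turns isobutyl into propyl on the same nitrogen, gives an at least 40-fold higher number from compound 2 to compound 4 (1.60 log units; beyond the scatter), so both steps reach the same compound and both start from a limit. Among the compounds shown here, compound 4 is the only compound with a number rather than a limit: the limit of <= 1000 nM in this assay, at which 3 of the 4 values shown sit.

As far as these compounds go, whether the high reading is specific to propyl remains open, as ethyl, a longer chain such as butyl, or a chain carrying an amine on the sulfonamide nitrogen would show. Also open, from the compounds shown here alone, is whether propyl gives a similar reading with (methylsulfonyl)methyl in place of acetyl.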